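Adding an Isopropyl Group to an Amide Nitrogen

This account rests on a few compounds, and the source may have more. Where it says the series, first, only, none or still open, it means among the compounds named here.

Compound 1 `CCCCNc1nc(N)nc2cccc(OC)c12`: 0.1 uM
Compound 2 `CCCCNc1nc(N)nc2cccc(OCc3ccccn3)c12`: 18.5 uM
Compound 3 `CCCCNc1nc(N)nc2cccc(C(=O)NC)c12`: 0.39 uM

All three compounds share one core and were tested in an ADME assay on HEK293 cells for agonist activity at Toll-like receptor 8 (Homo sapiens), read by a luciferase reporter, with a stated time of 6 h; a lower number here means that less compound is needed, a higher number that more compound is needed for the effect. Compound 3 stands second highest of the three numbers: it sits a 3.9-fold higher number from compound 1 to compound 3 (0.59 log units; beyond the scatter) from compound 1 and, in the other direction, a 47-fold lower number from compound 2 to compound 3 (1.68 log units; beyond the scatter) from compound 2. The change that led to compound 2, a 190-fold higher number from compound 1 to compound 2 (2.27 log units; beyond the scatter), shows that a larger group at that side of the core can cost a great deal.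

Compound 4 `CCCCNc1nc(N)nc2cccc(C(=O)N(C)C(C)C)c12` differs from compound 3 in one place: isopropyl in place of hydrogen on an amide-type nitrogen. The amide carries a methyl already; compound 4 turns methylcarbamoyl into isopropyl(methyl)carbamoyl.

For the measured compounds named here, no measured step changes the same amide-type nitrogen, so the bearing of the earlier steps is indirect. Both a 3.9-fold higher number from compound 1 to compound 3 (0.59 log units; beyond the scatter) and a 190-fold higher number from compound 1 to compound 2 (2.27 log units; beyond the scatter) point the same way, with a higher number following each enlargement of that side of the core, and the isopropyl group is smaller than the group that entered in compound 2. A modest rise in this assay is therefore expected for compound 4, namely a 3.8-fold higher number from compound 3 to compound 4 (0.59 log units; beyond the scatter). The estimate for compound 4 is 1.5 uM, with a range from 0.3 uM to 8 uM.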

Compound 4, minimum effective concentration: > 25 uM
Compound 4: only a limit was reported; the forecaster's own chance of this, stated with the estimate: 10%; at least 16-fold (1.22 log units) between middle value and limit.
By their numbers in this assay, from the lowest: compound 1; then compound 3; then compound 2. At a limit, above all of these: compound 4.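

Compound 4 has only a limit of the assay, not a number: the limit of > 25 uM in this assay, at which 1 of the 4 values shown sits.

Even so, the step is large: an at least 64-fold higher number from compound 3 to compound 4 (1.80 log units; beyond the scatter). The earlier compounds shown here showed a high cost only when a (pyridin-2-yl)methoxy group entered, whereas here an isopropyl group of 3 carbon atoms, with no ring, placed on the amide-type nitrogen of an otherwise unchanged methylcarbamoyl group, is enough to produce a large rise, so this nitrogen is far less forgiving than the modest step from methoxy to methylcarbamoyl suggested. Measured against the methoxy compound, the gap is also large, an at least 250-fold higher number from compound 1 to compound 4 (2.39 log units; beyond the scatter), while the other new step, an at least 1.3-fold higher number from compound 2 to compound 4 (0.13 log units; that floor lies within the scatter), gives a floor that does not settle the order of that pair.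

The compounds shown do not separate the loss of the amide hydrogen from the arrival of the extra carbons, a question that an isopropylcarbamoyl group, which keeps that hydrogen, and a dimethylcarbamoyl group, which loses it, could help to divide. On these data alone, how far the true number lies past the limit also stays open, as does whether an ethyl group on the same nitrogen would be tolerated.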